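Aryl amine swap on the shared core: outlook for compound 3

A few compounds are considered here, and "the series" means these few. Any claim that something is new, unique, unknown or untested is made for them only; others in the source may bear on it.

Measured so far:
compound 1 `CC1(OC(=O)N2C[C@H]3COC[C@@H](C2)[C@@H]3Oc2ncnc(Nc3ccccc3F)c2F)CC1`: 76%
compound 2 `CC1(OC(=O)N2CC3COCC(C2)C3Oc2ncnc(Nc3ccc(F)cc3F)c2F)CC1`: 73%

In a functional assay for agonist activity at Glucose-dependent insulinotropic receptor (Mus musculus), read by cAMP accumulation (on this read-out higher numbers stand for larger maximal responses and lower numbers for smaller maximal responses), compound 1 gives 76% and compound 2 gives 73%. Of the two numbers, compound 2 holds the smaller one, but compound 1 sits within the scatter of it, so the two maximal responses are not distinguished. Among the compounds with values here, no pair of measured compounds differs in a single place, so no measured step is available to calibrate the next change.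

Compound 3 `CC1(OC(=O)N2CC3COCC(C2)C3Oc2ncnc(Nc3cccnc3Cl)c2F)CC1` is not yet measured. Against compound 2 it shows (2-chloropyridin-3-yl in place of 2,4-difluorophenyl on a nitrogen on an aromatic ring). Within the data shown here, with both measured maximal responses close together and no comparable step on record, the step from compound 2 to compound 3 is expected to be small, a number 3 percentage points lower from compound 2 to compound 3 (within the scatter), in no firm direction and possibly not beyond the scatter. Compound 3 is therefore estimated at 70%, with a range from 55% to 85%.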

Compound 3, largest response reached (reported as percent of maximum), in percent of the reference or control that the assay uses: 84%
For compound 3 the middle estimate is 14 percentage points below the measured one, and the stated range covers the measured number.
By their numbers in this assay, from the lowest: compounds 2, 1 and 3 (each within the scatter of the next, the first and the last beyond it).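

Swapping 2,4-difluorophenyl for 2-chloropyridin-3-yl on a nitrogen on an aromatic ring gives, in this assay, a number 11 percentage points higher from compound 2 to compound 3 (beyond the scatter) on the shared core. Within the data shown here, this is the first single-place step on record for the series, and it shows that the maximal response responds to the aryl group at this position and that this exchange raises it. No measurement at hand explains the gain.

On these data alone, the exchange changes several things at once, as the ring nitrogen and chlorine enter together while both fluorines leave, so the share of each in the step stays open. Also open, as far as these compounds go, is how far the response moves with other groups on this nitrogen, such as an unsubstituted phenyl, a methoxy-bearing pyridine or a small alkyl chain, and whether the step holds on other cores.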